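Working notes: amide substituent change from compound 1 to compound 3

The source may hold more compounds than are shown below. What is called first, only, known or untested is meant among the compounds shown, and "the series" means these compounds.

Among the compounds with values here, compound 1 `Cc1cccc(CNC(=O)c2nn(-c3ccc(F)cc3)c(OC[C@@H](O)C[C@@H](O)CC(=O)O)c2C(C)C)c1` gives 280 nM in a functional assay on L6 cells (Rattus norvegicus) for inhibition (a lower number here means a stronger inhibitor, a higher number a weaker inhibitor), the lower of the two numbers measured so far. Compound 2 `Cc1ccccc1CNC(=O)c1nn(-c2ccc(F)cc2)c(OC[C@@H](O)C[C@@H](O)CC(=O)O)c1C(C)C` gives 2850 nM in this assay. Within the data shown here, the only measured step, a 10-fold higher number from compound 1 to compound 2 (1.01 log units; beyond the scatter), is large. Compound 3 `CC(C)c1c(C(=O)N(C)Cc2cccc(Cl)c2)nn(-c2ccc(F)cc2)c1OC[C@@H](O)C[C@@H](O)CC(=O)O` differs from compound 1 by (3-chlorobenzyl)(methyl)amino in place of (3-methylbenzyl)amino on a carbonyl carbon. Among the measured compounds shown here, that step concerns 2-methylphenyl in place of 3-methylphenyl, a different change, so no measured step bears directly on this replacement, and the direction is uncertain. Compound 3 is expected to show a modest weakening, a step of a 2.3-fold higher number from compound 1 to compound 3 (0.37 log units; beyond the scatter), estimated at 650 nM with a range from 150 nM to 2800 nM.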

Compound 3, half-maximal inhibitory concentration: 2120 nM
Compound 3: the middle estimate sits 3.3-fold (0.51 log units) below what was measured; low and high end bracket the measured number.
By their numbers in this assay, from the lowest: compound 1; then compounds 3 and 2 (each within the scatter of the next).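

Working notes: with (3-chlorobenzyl)(methyl)amino in place of (3-methylbenzyl)amino on a carbonyl carbon, this assay gives a modest loss (a 7.6-fold higher number from compound 1 to compound 3 (0.88 log units; beyond the scatter)), so a second change at this amide also falls short of compound 1. The comparison with the ortho-free label aside, the other new step (a 1.3-fold lower number from compound 2 to compound 3 (0.13 log units; within the scatter)) sets no order between those two compounds. No evidence accounts for the loss.

As far as these compounds go, this change alters the amide hydrogen and the ring substituent together, so their separate contributions remain open. From the compounds shown here alone, whether (3-chlorobenzyl)amino or (3-methylbenzyl)(methyl)amino would match compound 1 also remains open.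

Correction to the second sentence above, which should read: The other new step (a 1.3-fold lower number from compound 2 to compound 3 (0.13 log units; within the scatter)) sets no order between those two compounds.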